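Methyl on the phenyl of a pyrazolyl urea series

The source may hold more compounds than are shown below. What is called first, only, known or untested is meant among the compounds shown, and "the series" means these compounds.

Compound 1 `CC(C)(C)c1cc(NC(=O)Nc2cc(C(F)(F)F)cc(C(F)(F)F)c2)n(-c2ccccc2)n1`: 0.8 degrees C
Compound 2 `Cc1ccc(-n2nc(C(C)(C)C)cc2NC(=O)Nc2cc(C(F)(F)F)cc(C(F)(F)F)c2)cc1`: 0.8 degrees C
Compound 3 `CC(C)(C)c1cc(NC(=O)Nc2cc(F)cc(F)c2)n(-c2ccccc2)n1`: 2.7 degrees C

All three were tested in an assay on isolated protein for inhibition of Ephrin type-A receptor 2 (Homo sapiens), read by thermal shift assay, tested at 10 uM; on this read-out lower numbers stand for weaker stabilisation of the target and higher numbers for stronger stabilisation of the target against heat. Compound 3 stands highest, with the strongest stabilisation of the three. Compound 1 and compound 2 lie within the scatter of each other; the step of no change at the digits printed from compound 1 to compound 2 (within the scatter) corresponds to the change (methyl in place of hydrogen on an aromatic carbon). How the core of compound 3 differs from that of compound 1 is not broken down here. Compound 4 `Cc1ccc(-n2nc(C(C)(C)C)cc2NC(=O)Nc2cc(F)cc(F)c2)cc1` has not yet been measured in this assay; it carries the same change relative to compound 3, namely (methyl in place of hydrogen on an aromatic carbon), at a place described in the same words. Because the earlier step of no change at the digits printed from compound 1 to compound 2 (within the scatter) stayed within the scatter, the step of no change at the digits printed from compound 3 to compound 4 (within the scatter) is expected to be small as well. Compound 4 is therefore estimated at 2.7 degrees C, between 1.5 degrees C and 3.9 degrees C.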

Compound 4, shift of the target's melting temperature: 1.9 degrees C
For compound 4 the middle estimate is 0.80 degrees C above the measured one; low and high end bracket the measured number.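

Phenyl to 4-methylphenyl on the core of compound 3 gives, in this assay, a number 0.80 degrees C lower from compound 3 to compound 4 (within the scatter). Set beside the same change on the core of compound 1, the two steps cannot be told apart: the same change on two cores in this assay, no change at the digits printed (within the scatter) from compound 1 to compound 2 and a number 0.80 degrees C lower (within the scatter) from compound 3 to compound 4, 0.80 degrees C apart, within the scatter of two such steps. This supports carrying the methyl between these two cores without a clear effect on the read-out, but two pairs show no general rule for the series, and scatter of this size could hide a modest real difference between the cores.

The compounds shown leave open what a chlorine, a methoxy or an amine would do at the same place on the phenyl. They also leave open whether a longer chain there would keep the read-out as the methyl does.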